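This account rests on a few compounds, and the source may have more. Where it says the series, first, only, none or still open, it means among the compounds named here.

Working notes on the series. The shared core of compound 1 `N/C(=N\NC(=S)N1CCOCC1)c1ccccn1` gives, in a functional assay on MCF7 cells (Homo sapiens) for cytotoxicity, read by MTT assay, with a stated time of 72 h (on this read-out lower numbers stand for stronger inhibition and higher numbers for weaker inhibition), compound 1 a value of 4700 nM. Compound 2 `Cc1ccnc(/C(N)=N/NC(=S)N2CCOCC2)c1` reaches only a limit in this assay, where compound 2 gives > 100000 nM; this is the limit of > 100000 nM in this assay, at which 1 of the 3 values shown sits. Compound 3 `Cc1cccc(/C(N)=N/NC(=S)N2CCOCC2)n1` gives 21500 nM in this assay, the highest of the two numbers shown, with compound 1 the nearest. The two steps measured so far, an at least 21-fold higher number from compound 1 to compound 2 (1.32 log units; beyond the scatter) and a 4.6-fold higher number from compound 1 to compound 3 (0.66 log units; beyond the scatter), both concern a methyl in place of hydrogen on an aromatic carbon and leave the thiocarbonyl end of the core untouched.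

Compound 4 `Cc1cccc(/C(N)=N/NC(=S)N2CCCC2)n1` differs from compound 3 at that end: pyrrolidin-1-yl in place of morpholin-4-yl on a thiocarbonyl carbon. For the measured compounds named here, no measured step bears on this change, so its effect in this assay rests on no comparison. The working expectation is therefore a step of a 1.1-fold lower number from compound 3 to compound 4 (0.03 log units; within the scatter), with a wide range either way. Compound 4 is estimated at 20000 nM in this assay, between 5000 nM and 80000 nM.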

Compound 4, half-maximal inhibitory concentration: 61800 nM
For compound 4 the middle estimate is 3.1-fold (0.49 log units) below the measured one; the range from low to high includes it.
By their numbers in this assay, from the lowest: compound 1; then compound 3; then compound 4. At a limit, above all of these: compound 2.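

In this assay, the change on the thiocarbonyl carbon gives a 2.9-fold higher number from compound 3 to compound 4 (0.46 log units; beyond the scatter) and so shows that this end of the core is not neutral to substitution, at least on the methyl-bearing core of compound 3. The earlier steps shown here concerned only the methyl on the aromatic carbon; this pair adds that replacing morpholin-4-yl with pyrrolidin-1-yl, which removes the ring oxygen and its counted hydrogen-bond acceptor, goes with a higher number. With one pair, that is an association and no more, and nothing shown accounts for the step.

As far as these compounds go, whether the same change has a similar effect on the core of compound 1 remains open. Also open, from the compounds shown here alone, is how piperidin-1-yl, or an open-chain dimethylamino group, would stand on the thiocarbonyl carbon.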